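Swapping the aryl group on the vinyl carbon of compound 1

The source may report more compounds than this note shows. Statements on the series, on what has been measured and on what is new or still open speak of the compounds shown alone.

In a functional assay on DU-145 cells (Homo sapiens) for inhibition, read by trypan blue exclusion, with a stated time of 96 h (on this read-out higher numbers stand for weaker inhibition of growth and lower numbers for stronger inhibition of growth), compound 1 `CSc1ccc(/C=C(\C(=O)c2ccc(Cl)cc2)S(=O)(=O)Cc2ccc(C)cc2)cc1` gives 10000 nM, level with compound 3 `CSc1ccc(/C=C(\C(=O)c2ccc(Br)cc2)S(=O)(=O)Cc2ccc(C)cc2)cc1`, which gives 10000 nM; compound 2 `COc1ccc(S(=O)(=O)/C(=C/c2ccc(Br)cc2)C(=O)c2ccc(Br)cc2)cc1` gives 6000 nM, and none of these three differ beyond the scatter. Among the compounds with values here, the only one-place step among them, no change at the digits printed from compound 1 to compound 3 (within the scatter), concerns a halogen on the aryl ketone and not the aryl group on the double bond. Compound 4 `Cc1ccc(CS(=O)(=O)/C(=C/c2cc(C)ccc2C)C(=O)c2ccc(Cl)cc2)cc1` differs from compound 1 by 2,5-dimethylphenyl in place of 4-(methylsulfanyl)phenyl on a double-bonded chain carbon bound to a double-bonded chain carbon. Within the data shown here, no measured step bears on this change, so no shift beyond the scatter is expected in this assay; the estimated step is no change at the digits printed from compound 1 to compound 4 (within the scatter). Compound 4 is therefore expected to give 10000 nM, within a range of 4000 nM to 25000 nM.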

Compound 4, concentration for 50% growth inhibition: 1000 nM
Compound 4: middle estimate off by 10-fold (1.00 log units), on the high side; measured number outside the range, below it.
By their numbers in this assay, from the lowest: compound 4; then compounds 2, 1 and 3 (each within the scatter of the next).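

Unlike the halogen swap on the aryl ketone, which gave no change at the digits printed from compound 1 to compound 3 (within the scatter), the aryl group on a double-bonded chain carbon bound to a double-bonded chain carbon does move the read-out in this assay. Putting 2,5-dimethylphenyl in place of 4-(methylsulfanyl)phenyl gives a 10-fold lower number from compound 1 to compound 4 (1.00 log units; beyond the scatter). No measurement at hand accounts for this shift.

This single step does not separate losing the methylsulfanyl group from gaining the two methyl groups. From the compounds shown here alone, how a simple phenyl, a single methyl or an amine on this aryl group would read remains open.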